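Carbamate series: pyridin-3-yl ester in place of phenyl

This account rests on a few compounds, and the source may have more. Where it says the series, first, only, none or still open, it means among the compounds named here.

Measured so far:
compound 1 `O=C(NCCCCCn1ccc2ccccc21)Oc1ccccc1` — 94 nM
compound 2 `O=C(NCCCCn1ccc2ccccc21)Oc1ccccc1` — 960 nM
compound 3 `Cc1c(C#N)c(-c2ccccc2)c(-c2ccccc2)n1CCCCCCNC(=O)Oc1ccccc1` — 8700 nM

In an assay on microsomes from brain (strain Sprague-Dawley) for inhibition of Fatty-acid amide hydrolase 1 (Rattus norvegicus), read by fluorescence and HPLC, with stated times of 10 min and 60 min (on this read-out higher numbers stand for weaker inhibition and lower numbers for stronger inhibition), compound 1 stands at the lowest number of the three; compound 2 and compound 3 both give higher numbers, and each of those gaps lies beyond the scatter. Compound 4 `O=C(NCCCCCn1ccc2ccccc21)Oc1cccnc1` has not been measured. It differs from compound 1 by pyridin-3-yl in place of phenyl on an oxygen next to a carbonyl group. Among the compounds with values here, no pair among the measured compounds covers this kind of exchange, so the size of the step is not anchored by the numbers in hand. The expectation is a small step, within or just beyond the scatter, with no firm direction. Compound 4 is estimated at 100 nM (range 30 nM to 350 nM), which would be a step of a 1.1-fold higher number from compound 1 to compound 4 (0.03 log units; within the scatter).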

Compound 4, half-maximal inhibitory concentration: 3.6 nM
Beside the measured number, compound 4's estimate is 28-fold (1.44 log units) above it; measured number below the stated range.
By their numbers in this assay, from the lowest: compound 4; then compound 1; then compound 2; then compound 3.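

In this assay, within the data shown here, pyridin-3-yl in place of phenyl on an oxygen next to a carbonyl group gives a 26-fold lower number from compound 1 to compound 4 (1.42 log units; beyond the scatter) and so shows that this position, the same phenyl in all the earlier compounds, responds strongly to the change. The two groups have the same heavy-atom count, and one ring carbon exchanged for nitrogen is the whole difference. Nothing in hand accounts for the size of this step. Still open, as far as these compounds go, is whether pyridin-2-yl or pyridin-4-yl would match pyridin-3-yl here. Also open, from the compounds shown here alone, is whether a longer chain would keep the gain.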